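Half-life in rat liver microsomes across an aryl swap

The source may hold more compounds than are shown below. What is called first, only, known or untested is meant among the compounds shown, and "the series" means these compounds.

Compound 1 `Cc1ccccc1-c1nc(CN2CCC(C(=O)NCCCN3CCC(C)CC3)CC2)c(C)o1`: > 0.5 h
Compound 2 `Cc1oc(-c2c(Cl)cccc2Cl)nc1CN1CCC(C(=O)NCCCN2C[C@H](C)C[C@H](C)C2)CC1`: 0.0483 h

In an ADME assay on microsomes from liver (Rattus norvegicus) for metabolic stability, read by LC-MS, using NADPH, at 37 degrees C (a lower number here means that the compound disappears faster, a higher number that the compound lasts longer), compound 1 reaches only a limit of the assay, > 0.5 h, so it is not a number. Compound 2 gives the one number shown, 0.0483 h, a short half-life. Compound 3 `COc1cccc(C)c1-c1nc(CN2CCC(C(=O)NCCCN3C[C@H](C)C[C@H](C)C3)CC2)c(C)o1` is not yet measured; it differs from compound 2 by 2-methoxy-6-methylphenyl in place of 2,6-dichlorophenyl on an aromatic carbon. Within the data shown here, with no measured step of this kind available, the direction of the change is uncertain, and compound 3 is expected to lie at 0.15 h (range 0.04 h to 0.6 h), a modest expected lengthening a 3.1-fold higher number from compound 2 to compound 3 (0.49 log units; beyond the scatter) that may not exceed the scatter.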

Compound 3, half-life: 0.0767 h
For compound 3 the middle estimate is 2.0-fold (0.29 log units) above the measured one, and the stated range covers the measured number.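

Among these compounds, replacing 2,6-dichlorophenyl with 2-methoxy-6-methylphenyl on this aromatic carbon gives the first readable step at this position in this assay: a 1.6-fold higher number from compound 2 to compound 3 (0.20 log units; within the scatter). This exchange therefore leaves the half-life within the usual scatter of the assay. Nothing shown here gives a cause for this step.

Compound 1 differs from compound 2 and compound 3 in more than one place, so its half-life cannot be tied to this position alone. On these data alone, whether an aryl group bearing a nitrile or a trifluoromethyl would change the half-life beyond the scatter remains open.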